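Working notes on a bromo-to-fluoro exchange

A few compounds are considered here, and "the series" means these few. Any claim that something is new, unique, unknown or untested is made for them only; others in the source may bear on it.

Two compounds of the series carry numbers in a functional assay on K562 cells (Homo sapiens) for inhibition, read by MTT assay, with a stated time of 72 h; on this read-out higher numbers stand for weaker inhibition and lower numbers for stronger inhibition. Compound 1 `CCc1cc(CC)c(C(=O)/C=C/C(=O)O)c(CC)c1` gives 4010 nM. Compound 2 `O=C(O)/C=C/C(=O)c1ccc(Br)cc1` gives 11200 nM, the highest of the two numbers; the nearest is compound 1, whose lower number lies beyond the scatter. Compound 3 `O=C(O)/C=C/C(=O)c1ccc(F)cc1` has not yet been measured. It differs from compound 2 in one place: fluoro in place of bromo on an aromatic carbon. Among the measured compounds shown here, no step of this kind between measured compounds is available, so the size of such a change cannot be read from the data themselves. In this assay the expected step from compound 2 to compound 3 is small, at most slightly toward a higher number, and quite possibly within the scatter, amounting to a 1.3-fold higher number from compound 2 to compound 3 (0.13 log units; within the scatter). Compound 3 is accordingly estimated at 15000 nM, with a range from 6000 nM to 40000 nM.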

Compound 3, half-maximal inhibitory concentration: 16900 nM
Estimate against measurement, compound 3: 1.1-fold (0.05 log units) below; the measured number falls inside the stated range.
By their numbers in this assay, from the lowest: compound 1; then compounds 2 and 3 (each within the scatter of the next).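

The exchange of bromo for fluoro gives the series its first step in one place, and in this assay it amounts to a 1.5-fold higher number from compound 2 to compound 3 (0.18 log units; within the scatter). Among the compounds shown here, on an aromatic carbon para to a group of 7 heavy atoms, the two halogens are therefore not separated on this read-out, although the earlier compounds gave no size for such a change. No measurement of any property of these compounds bears on this result.

On these data alone, whether an amine, a methoxy group or a nitrile on this same carbon would move the number beyond the scatter remains open. Equally open, as far as these compounds go, is what an amide in place of the carboxylic acid would do on the shared core.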